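This account rests on a few compounds, and the source may have more. Where it says the series, first, only, none or still open, it means among the compounds named here.

Measured compounds:

compound 1, `O=C(/C=C/c1ccc2c(c1)B(O)OC2)c1ccc(Cl)cc1` — in a functional assay on HCT-116 cells (Homo sapiens) for cytotoxicity, read by MTT assay, with a stated time of 48 h (on this read-out lower numbers stand for stronger inhibition and higher numbers for weaker inhibition), compound 1 gives 9300 nM
compound 2, `O=C(/C=C/c1ccc2c(c1)B(O)OC2)c1ccc(Br)cc1` — in this assay compound 2 gives 9900 nM

On the numbers shown, compound 2 stands at the top of the pair on paper, with compound 1 as its only neighbour, yet the step of a 1.1-fold higher number from compound 1 to compound 2 (0.03 log units; within the scatter) lies within the scatter, so the two compounds cannot be told apart in this assay.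

Compound 3, `O=C(/C=C/c1ccc2c(c1)B(O)OC2)c1ccc(I)cc1`, has not yet been measured. It differs from compound 2 in one place: iodo in place of bromo on an aromatic carbon. Going by the values given here, the one measured step that bears on this change is the exchange of one halogen for the next on the same aromatic carbon, a 1.1-fold higher number from compound 1 to compound 2 (0.03 log units; within the scatter), which produced no movement beyond the scatter. The change from compound 2 to compound 3 is of the same kind, one halogen further along, and the data give no ground to expect anything different from it.

Compound 3 is therefore expected to show a step of a 1.0-fold higher number from compound 2 to compound 3 (0.00 log units; within the scatter) in this assay, that is, none beyond the scatter. The estimate for compound 3 is 10000 nM, with a range from 5000 nM to 20000 nM.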

Compound 3, half-maximal inhibitory concentration: 11600 nM
Compound 3: the middle estimate sits 1.2-fold (0.06 log units) below what was measured; the measured number falls inside the stated range.
By their numbers in this assay, from the lowest: compounds 1, 2 and 3 (each within the scatter of the next).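

At this place, on an aromatic carbon of a six-membered aromatic ring of carbon only and para to a large group, the exchange of bromo for iodo in this assay gives a step that stays within the scatter (a 1.2-fold higher number from compound 2 to compound 3 (0.07 log units; within the scatter)), and the direct exchange of chloro for iodo does the same (a 1.2-fold higher number from compound 1 to compound 3 (0.10 log units; within the scatter)). The earlier compounds showed this for a single exchange, whereas the three halogens can now be compared pairwise, and none of the listed steps among them lies beyond the scatter, including the one from the 4-chlorophenyl compound to the 4-iodophenyl compound. No supporting measurement is available to explain why these three compounds cannot be told apart in this cell read-out.

The compounds shown all carry a halogen at this place, so they leave open whether an amine, a carboxylic acid, a methoxy group or plain hydrogen there would give a number beyond the scatter of these three. They also leave open whether a halogen exchange on another carbon of this ring, or any change to the shared core, would behave in the same way.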